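Notes on a ring substituent swap in a small series

This account rests on a few compounds, and the source may have more. Where it says the series, first, only, none or still open, it means among the compounds named here.

Measured compounds:
compound 1, `O=c1oc(-c2ccccc2I)nc2ccc(Cl)cc12`, 27300 nM
compound 2, `Cc1ccc2c(=O)oc(-c3ccccc3I)nc2c1`, > 62500 nM

In an assay on isolated protein for inhibition of complement C1r subcomponent (Homo sapiens) (on this read-out lower numbers stand for stronger inhibition and higher numbers for weaker inhibition), compound 1 gives 27300 nM. For compound 2 the result is only a limit, > 62500 nM, so its place on the numbers is open at the weaker end. Compound 2 stands at the limit of > 62500 nM in this assay, at which 1 of the 2 values shown sits. Compound 3, `O=c1oc(-c2ccccc2I)nc2cc([N+](=O)[O-])ccc12`, is not yet measured; it differs from compound 2 by nitro in place of methyl on an aromatic carbon. Among the measured compounds shown here, no measured pair shows this change, so the size of the step rests on judgement alone. In this assay a move back into the measurable range is expected for compound 3, though the step from compound 2 to compound 3 may well stay within the usual scatter, and a second limit result is a real possibility. The estimate for compound 3 is 40000 nM, with a range from 10000 nM to 120000 nM, which corresponds to an expected step of an at least 1.5-fold lower number from compound 2 to compound 3 (0.19 log units; that floor lies within the scatter).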

Compound 3, half-maximal inhibitory concentration: > 62500 nM
Compound 3 was reported as a limit (the forecaster's own chance of this, stated with the estimate: 45%); at least 1.5-fold (0.19 log units) between middle value and limit.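

In this assay compound 3 gives only a limit, > 62500 nM. Compound 2 also gives only a limit, so no step can be read between compound 2 and compound 3: the limit of > 62500 nM in this assay, at which 2 of the 3 values shown sit.

The compounds shown leave open whether nitro in place of methyl on an aromatic carbon changes the read-out at all, and in which direction.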